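A Methoxy Becomes a Hydroxy on the Aromatic Ring

This account rests on a few compounds, and the source may have more. Where it says the series, first, only, none or still open, it means among the compounds named here.

Compound 2 `COc1cc([C@H]2CC(C)(F)[C@@H]3CC[C@@H](C)C[C@H]3O2)cc(OC)c1OC` was tested in an ADME assay on MDCK cells (Canis lupus familiaris) for cytotoxicity, read by MTT assay, with a stated time of 48 h (a lower number here means that less compound is tolerated, a higher number that more compound is tolerated), where compound 2 gives 568000 nM. Among the compounds with values here, the only other compound measured, compound 1 `COc1cc([C@H]2CC(C)(O)[C@@H]3CC[C@@H](C)C[C@H]3O2)cc(OC)c1OC`, gives 405000 nM in this assay. The two numbers cannot be told apart, since the step of a 1.4-fold higher number from compound 1 to compound 2 (0.15 log units; within the scatter) lies within the scatter; on the numbers shown, compound 2 therefore sits alongside compound 1 rather than apart from it.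

Compound 3 `COc1cc([C@H]2CC(C)(F)[C@@H]3CC[C@@H](C)C[C@H]3O2)cc(OC)c1O` has not yet been measured. It differs from compound 2 by hydrogen in place of methyl on an oxygen on an aromatic ring. Within the data shown here, no measured step bears directly on this change: the one step available, from compound 1 to compound 2, concerned a saturated ring carbon and was small. Among the measured compounds shown here, nothing among the measured compounds points to a move in either direction beyond the scatter for compound 3.

The expectation for compound 3 is thus a number close to that of compound 2, with an expected step of a 1.1-fold lower number from compound 2 to compound 3 (0.06 log units; within the scatter). The estimate for compound 3 in this assay is 500000 nM, with a range from 250000 nM to 1000000 nM.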

Compound 3, half-maximal cytotoxic concentration: 158000 nM
Estimate against measurement, compound 3: 3.2-fold (0.50 log units) above, outside the stated range (below it).
By their numbers in this assay, from the lowest: compound 3; then compounds 1 and 2 (each within the scatter of the next).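

In this assay, the change from methoxy to hydroxy on the aromatic ring produces the first step among these compounds that stands clear of the scatter (a 3.6-fold lower number from compound 2 to compound 3 (0.56 log units; beyond the scatter)), so the cells tolerate less of compound 3. The step is modest, but it shows that this oxygen on the aromatic ring is a place where a single small change can move the number. The earlier change on a saturated ring carbon did not show this, as its step (a 1.4-fold higher number from compound 1 to compound 2 (0.15 log units; within the scatter)) stayed within the scatter, although one step at each place cannot establish a general rule. The data offer no measured explanation for the lower number in compound 3.

The compounds shown leave open whether the number falls further, recovers or stays put when another group, such as an amine, a carboxylic acid or a longer ether chain, takes the place of the methoxy. They also leave open whether the same change from methoxy to hydroxy on the other methoxy groups of the ring would give a step of similar size.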